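A few compounds are considered here, and "the series" means these few. Any claim that something is new, unique, unknown or untested is made for them only; others in the source may bear on it.

Working notes on the series. Going by the values given here, in a functional assay (trachea) for inhibition, with Cavia porcellus as the target (a lower number here means a stronger inhibitor, a higher number a weaker inhibitor), compound 2 `CC1(C)Oc2ccc(C#N)cc2[C@@H](N2CCCCC2=O)[C@@H]1O` gives 270 nM, the only number obtained so far. Compound 1 `CC1(C)Oc2ccc(C#N)cc2[C@@H](N2CCC2=O)[C@@H]1O` gives > 20000 nM, which is a limit of the assay and not a number; it sits at the limit of > 20000 nM in this assay, at which 1 of the 2 values shown sits. Among the compounds with values here, the single measured step is an at least 74-fold lower number from compound 1 to compound 2 (1.86 log units; beyond the scatter), 2-oxopiperidin-1-yl for 2-oxoazetidin-1-yl. Compound 3 `CC1(C)Oc2ccc(C#N)cc2[C@@H](n2ccccc2=O)[C@@H]1O` carries a group of 7 heavy atoms (5 carbon, 1 nitrogen, 1 oxygen; one six-membered aromatic ring with 1 hetero atom) in place of a group of 7 heavy atoms (5 carbon, 1 nitrogen, 1 oxygen; one six-membered non-aromatic ring with 1 hetero atom), on a saturated ring carbon. That measured step does not bear directly on this exchange, so a step of modest size at most is expected, if any, in this assay. The expected step is a 1.7-fold higher number from compound 2 to compound 3 (0.22 log units; within the scatter). Compound 3 is estimated at 450 nM, between 100 nM and 3000 nM.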

Compound 3, half-maximal inhibitory concentration: 760 nM
Estimate against measurement, compound 3: 1.7-fold (0.23 log units) below; measured number inside the range.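

In this assay, replacing the non-aromatic 2-oxopiperidin-1-yl with the six-membered aromatic ring at this saturated ring carbon costs only a modest amount (a 2.8-fold higher number from compound 2 to compound 3 (0.45 log units; beyond the scatter)). A measured number therefore does not depend on the non-aromatic ring, and both six-membered rings stand well clear of the four-membered ring of compound 1 (an at least 26-fold lower number from compound 1 to compound 3 (1.42 log units; beyond the scatter)). The value of compound 1 is a limit of the assay and not a number: the limit of > 20000 nM in this assay, at which 1 of the 3 values shown sits.

Going by these compounds, what a five-membered 2-oxopyrrolidin-1-yl would give here remains open. So does the outcome with an open-chain acetamido group, which would show whether a ring is needed at all.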